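Ester to alcohol on the amide side chain

The source may hold more compounds than are shown below. What is called first, only, known or untested is meant among the compounds shown, and "the series" means these compounds.

Compound 1 `CCn1c(C(=O)N[C@@H](C)C(=O)OC)ccc1C(CC)(CC)c1ccc(OCS(=O)(=O)c2ccccc2)c(C)c1` reaches only the assay limit of > 50000 nM in a functional assay on PC-3 cells (Homo sapiens) for antiproliferative activity, read by MTT assay, with a stated time of 24 h (a lower number here means a stronger inhibitor, a higher number a weaker inhibitor), a limit rather than a number. Compound 2 `CCn1c(C(=O)NCCC(=O)OC)ccc1C(CC)(CC)c1ccc(OCS(=O)(=O)c2ccccc2)c(C)c1` gives 40400 nM in this assay, the highest of the two numbers shown. Compound 3 `CCn1c(C(=O)N[C@@H](CO)C(C)C)ccc1C(CC)(CC)c1ccc(OCS(=O)(=O)c2ccccc2)c(C)c1` gives 10600 nM, a step of a 3.8-fold lower number from compound 2 to compound 3 (0.58 log units; beyond the scatter). The unmeasured compound 4 `CCn1c(C(=O)NCCCO)ccc1C(CC)(CC)c1ccc(OCS(=O)(=O)c2ccccc2)c(C)c1` differs from compound 2 by hydroxymethyl in place of methoxycarbonyl on a saturated chain carbon, two bonds along the chain from an amide-type nitrogen. The steps of a 3.8-fold lower number from compound 2 to compound 3 (0.58 log units; beyond the scatter) and an at least 4.7-fold lower number from compound 1 to compound 3 (0.67 log units; beyond the scatter), both toward an amide substituent carrying a hydroxymethyl group, bear on this change and point to a modest lowering. Compound 4 is therefore expected at about 18000 nM, between 7000 nM and 45000 nM. The expected step is a 2.2-fold lower number from compound 2 to compound 4 (0.35 log units; beyond the scatter).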

Compound 4, half-maximal inhibitory concentration: 11300 nM
Compound 4: the middle estimate sits 1.6-fold (0.20 log units) above what was measured; the measured number falls inside the stated range.
By their numbers in this assay, from the lowest: compounds 3 and 4 (each within the scatter of the next); then compound 2. At a limit, above all of these: compound 1.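

The direct swap of hydroxymethyl for methoxycarbonyl on a saturated chain carbon, two bonds along the chain from an amide-type nitrogen, gives in this assay a step of a 3.6-fold lower number from compound 2 to compound 4 (0.55 log units; beyond the scatter), with no other part of the structure changed. The unbranched 3-hydroxypropyl group cannot be told apart from the branched group of compound 3, with a 1.1-fold higher number from compound 3 to compound 4 (0.03 log units; within the scatter), so the branches are not required for this level. The step of an at least 4.4-fold lower number from compound 1 to compound 4 (0.64 log units; beyond the scatter) gives only a floor, since compound 1 stands at a limit: the limit of > 50000 nM in this assay, at which 1 of the 4 values shown sits.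

As far as these compounds go, what a carboxylic acid or an amine in place of methoxycarbonyl on that carbon would give remains open, as does the effect of a longer chain carrying the hydroxymethyl group.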